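Replacing Naphthalenyl with Chlorophenyl on a Sulfonamide Core

This account rests on a few compounds, and the source may have more. Where it says the series, first, only, none or still open, it means among the compounds named here.

compound 1 `Cc1cccc(S(=O)(=O)N2CCC(N3CCC(C)CC3)CC2)c1`: 25 nM
compound 2 `CC1CCN(C2CCN(S(=O)(=O)c3cccc(-c4ccc5ccccc5c4)c3)CC2)CC1`: 2 nM

In a functional assay on DLD-1 cells (Homo sapiens) for antiproliferative activity, read by CellTiter-Glo, with a stated time of 72 h (on this read-out lower numbers stand for stronger inhibition and higher numbers for weaker inhibition), compound 2 gives 2 nM, the lowest of the two numbers shown; its nearest neighbour is compound 1, which gives 25 nM. Compound 3 `CC1CCN(C2CCN(S(=O)(=O)c3cccc(-c4ccc(Cl)cc4)c3)CC2)CC1` differs from compound 2 in one place: 4-chlorophenyl in place of naphthalen-2-yl on an aromatic carbon. Going by the values given here, only one measured step bears on this change, a 13-fold lower number from compound 1 to compound 2 (1.10 log units; beyond the scatter), which shows that exchanging methyl for naphthalen-2-yl in that place lowered the number sharply. Compound 3 keeps an aryl group there, though a different one, so a modest move back toward compound 1 is expected. Compound 3 is therefore expected to give 6 nM, within 2 nM to 20 nM. The expected step is a 3.0-fold higher number from compound 2 to compound 3 (0.48 log units; beyond the scatter).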

Compound 3, half-maximal inhibitory concentration: 15 nM
For compound 3 the middle estimate is 2.5-fold (0.40 log units) below the measured one; measured number inside the range.
By their numbers in this assay, from the lowest: compound 2; then compounds 3 and 1 (each within the scatter of the next).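

The kind of aryl group at this aromatic carbon matters: with 4-chlorophenyl in place of naphthalen-2-yl, this assay shows a 7.5-fold higher number from compound 2 to compound 3 (0.88 log units; beyond the scatter) and so the low number of compound 2 does not come with just any aryl group. Set against methyl, 4-chlorophenyl gives a 1.7-fold lower number from compound 1 to compound 3 (0.22 log units; within the scatter) and so the two groups cannot be told apart here. Nothing measured here explains the gap between the two aryl groups.

Open still is whether plain phenyl would match 4-chlorophenyl. Also open, as far as these compounds go, is whether quinolin-3-yl, or an amine in place of the chlorine, would approach the number of compound 2.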